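The source may hold more compounds than are shown below. What is called first, only, known or untested is meant among the compounds shown, and "the series" means these compounds.

Working notes on the series.

Three compounds of this set carry a measured number in an assay on HEK293 cells for displacement of a labelled ligand from 5-hydroxytryptamine receptor 7 (Rattus norvegicus); a lower number here means a stronger inhibitor, a higher number a weaker inhibitor. Compound 1 `COc1ccccc1N1CCN(CCCCCC(=O)NC2CCCc3c(OC)cccc32)CC1` gives 20 nM and compound 2 `COc1ccc2c(c1)CCCC2NC(=O)CCCCCN1CCN(c2ccccc2OC)CC1` gives 30 nM; both are within the scatter of each other. Compound 3 `O=C(CCCCCN1CCN(c2noc3ccccc23)CC1)NC1CCCc2ccccc21` gives 125 nM, the highest number of the three, with the numbers of compound 2 and of compound 1 lower by amounts beyond the scatter. Compound 3 is therefore the weakest inhibitor among the measured ones.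

Compound 4 `O=C(CCCCCN1CCN(c2nc3ccccc3o2)CC1)NC1CCCc2ccccc21` is not yet measured. It differs from compound 3 in one place: a group of 9 heavy atoms (7 carbon, 1 nitrogen, 1 oxygen; one five-membered aromatic ring with 2 hetero atoms, one six-membered aromatic ring of carbon only) in place of a group of 9 heavy atoms (7 carbon, 1 nitrogen, 1 oxygen; one five-membered aromatic ring with 2 hetero atoms, one six-membered aromatic ring of carbon only), on an amine nitrogen in a ring. The two groups have the same atoms, joined differently, so the chain, the amide and the saturated bicyclic end are untouched.

Going by the values given here, no measured pair in the set shows this exchange, so the size of the step is not known from the data. The expectation for compound 4 is a modest move toward a higher number in this assay, beyond the scatter but not large, giving an estimated step of a 2.4-fold higher number from compound 3 to compound 4 (0.38 log units; beyond the scatter). For compound 4 the estimated value in this assay is 300 nM, with a range from 80 nM to 1200 nM.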

Compound 4, inhibition constant: 820 nM
Estimate against measurement, compound 4: 2.7-fold (0.44 log units) below; the measured number falls inside the stated range.
By their numbers in this assay, from the lowest: compounds 1 and 2 (each within the scatter of the next); then compound 3; then compound 4.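

Going by these compounds alone, the exchange on the amine nitrogen in the ring, with 1,3-benzoxazol-2-yl entering, gives a 6.6-fold higher number from compound 3 to compound 4 (0.82 log units; beyond the scatter) in this assay, the first step in the set that can be read at a single place. It shows that this position responds to how the atoms of the group are joined, and not only to which atoms are present: the heavy atoms, ring types, hydrogen-bond donor and acceptor counts and net charge are identical on both sides, while the chain, the amide and the saturated bicyclic end stay the same. Within the data shown here, nothing available explains why this rearrangement moves the number so far.

The compounds shown leave open whether the same exchange produces a step of similar size when the saturated bicyclic end carries a methoxy group, as in compound 1 and compound 2. Going by these compounds, they also do not show how a simple phenyl or a 2-pyridyl group on the same nitrogen would compare with either fused group, so it remains unknown which of the two groups lies nearer the usual behaviour of this position.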